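The source may hold more compounds than are shown below. What is called first, only, known or untested is meant among the compounds shown, and "the series" means these compounds.

Working notes on the series, read in a functional assay on ECa-109 cells (Homo sapiens) for cytotoxicity, read by MTT assay, with a stated time of 72 h; on this read-out lower numbers stand for stronger inhibition and higher numbers for weaker inhibition. Compound 1 (`O=C1C(=Cc2ccc(O)cc2)C(=O)N(c2ccc(Cl)cc2)N1c1ccc(Cl)cc1`) gives 34200 nM. Compound 2 (`O=C1C(=Cc2ccc(F)cc2)C(=O)N(c2ccc(Cl)cc2)N1c1ccc(Cl)cc1`) gives 35600 nM, and the two are joined by a 1.0-fold higher number from compound 1 to compound 2 (0.02 log units; within the scatter). Compound 3 (`COc1ccc(C=C2C(=O)N(c3ccc(Cl)cc3)N(c3ccc(Cl)cc3)C2=O)cc1OC`) gives no number, only a limit, > 128000 nM. Going by these compounds, its place among the values shown is the limit of > 128000 nM in this assay, at which 1 of the 3 values shown sits, so its true value stays open.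

Compound 4 (`O=C1C(=Cc2ccco2)C(=O)N(c2ccc(Cl)cc2)N1c1ccc(Cl)cc1`) keeps the shared core, and furan-2-yl takes the place of 3,4-dimethoxyphenyl on a double-bonded chain carbon bound to a double-bonded ring carbon: furan-2-yl in place of 3,4-dimethoxyphenyl on a double-bonded chain carbon bound to a double-bonded ring carbon.

Two measured steps change this same place, both ending at compound 3: an at least 3.7-fold higher number from compound 1 to compound 3 (0.57 log units; beyond the scatter) and an at least 3.5-fold higher number from compound 2 to compound 3 (0.55 log units; beyond the scatter). Both are bounds rather than exact sizes. Read in reverse, they show that the two replacements of 3,4-dimethoxyphenyl measured so far both give lower numbers, and neither compound goes against this. Furan-2-yl itself has not yet been measured in this series, so the comparison is indirect.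

In this assay, a move to a lower number is therefore expected, of about the size of those two steps, with compound 4 probably staying somewhat weaker than the values of compound 1 and compound 2 suggest. The estimated step is an at least 2.3-fold lower number from compound 3 to compound 4 (0.36 log units; beyond the scatter). The expected value for compound 4 is 55000 nM, with an estimated range from 25000 nM to 120000 nM.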

Compound 4, half-maximal inhibitory concentration: 14300 nM
For compound 4 the middle estimate is 3.8-fold (0.59 log units) above the measured one; measured number outside the range, below it.
By their numbers in this assay, from the lowest: compound 4; then compounds 1 and 2 (each within the scatter of the next). At a limit, above all of these: compound 3.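

In this assay, the place on a double-bonded chain carbon bound to a double-bonded ring carbon now shows a change that goes beyond the level shared by compound 1 and compound 2, with furan-2-yl giving a 2.5-fold lower number from compound 2 to compound 4 (0.40 log units; beyond the scatter) and a 2.4-fold lower number from compound 1 to compound 4 (0.38 log units; beyond the scatter). The earlier compounds shown here showed only that replacing 3,4-dimethoxyphenyl with a substituted phenyl gave lower numbers, whereas a five-membered aromatic ring with 1 hetero atom also works at this place and gives the lowest number of the series, with an at least 8.9-fold lower number from compound 3 to compound 4 (0.95 log units; beyond the scatter). That last step is only a bound, since compound 3 carries a limit and not a number: the limit of > 128000 nM in this assay, at which 1 of the 4 values shown sits.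

What the compounds shown leave open is whether the lower number goes with the smaller group, the five-membered ring or its ring oxygen, since furan-2-yl differs from the other groups in all three. Thiophen-2-yl, pyridin-3-yl or a phenyl carrying a carboxylic acid or an amine at this place would help to separate these readings.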